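From 2-phenylethenyl to thiophen-2-yl on compound 1

The source may hold more compounds than are shown below. What is called first, only, known or untested is meant among the compounds shown, and "the series" means these compounds.

Among the measured compounds shown here, in a functional assay on HeLa cells (Homo sapiens) for cytotoxicity, read by sulforhodamine B assay, with a stated time of 48 h (on this read-out lower numbers stand for stronger inhibition and higher numbers for weaker inhibition), compound 1 (`CC(=O)OC[C@H]1O[C@@H](n2cc(CN3C(=O)/C(=C\C=C\c4ccccc4)c4ccccc43)nn2)[C@H](OC(C)=O)[C@@H](OC(C)=O)[C@@H]1OC(C)=O`) gives 98100 nM as the only actual number. Compound 2 (`CC(=O)OC[C@H]1O[C@@H](n2cc(CN3C(=O)/C(=C/C=C/c4ccccc4)c4ccccc43)nn2)[C@H](OC(C)=O)[C@@H](OC(C)=O)[C@@H]1OC(C)=O`) stands at > 100000 nM as a limit. For the measured compounds named here, the one measured step of an at least 1.0-fold higher number from compound 1 to compound 2 (0.00 log units; that floor lies within the scatter) stays within the scatter and reflects only the fact that compounds 1 and 2 differ only in the configuration as drawn as its difference, so it gives no measure for compound 3 (`CC(=O)OC[C@H]1O[C@@H](n2cc(CN3C(=O)/C(=C\c4cccs4)c4ccccc43)nn2)[C@H](OC(C)=O)[C@@H](OC(C)=O)[C@@H]1OC(C)=O`). Compound 3 carries thiophen-2-yl in place of 2-phenylethenyl on a double-bonded chain carbon bound to a double-bonded ring carbon. The expected change is a 1.2-fold lower number from compound 1 to compound 3 (0.09 log units; within the scatter) in this assay, with no step beyond the scatter. Compound 3 is expected at 80000 nM (estimated range 30000 nM to 160000 nM).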

Compound 3, half-maximal inhibitory concentration: > 100000 nM
Compound 3 was reported as a limit; the forecaster's own chance of this, stated with the estimate: 50%; middle value at least 1.2-fold (0.09 log units) from the limit.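

In this assay, compound 3 stands at > 100000 nM, which is a limit and not a number. Among the compounds shown here, the step, an at least 1.0-fold higher number from compound 1 to compound 3 (0.00 log units; that floor lies within the scatter), therefore puts no size on thiophen-2-yl in place of 2-phenylethenyl, and it shows only that this change on a double-bonded chain carbon bound to a double-bonded ring carbon yields no measurable value. The compounds cannot be ranked at this position because their values gather at one limit: the limit of > 100000 nM in this assay, at which 2 of the 3 values shown sit.

As far as these compounds go, it remains open whether an amine, a carboxylic acid or a longer chain at this place would give a measurable number in this assay.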